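The source may report more compounds than this note shows. Statements on the series, on what has been measured and on what is new or still open speak of the compounds shown alone.

Measured so far in a functional assay on HepG2 cells (Homo sapiens) for inhibition, read by MTT assay, with a stated time of 72 h; a higher number here means a weaker inhibitor, a lower number a stronger inhibitor:
- compound 1 `CC(C)(C)n1cc2c(n1)C(=O)CC1(CCN(C(=O)c3cc(-c4ccc(Cl)cc4)nc4ccccc34)CC1)O2` gives 630 nM
- compound 2 `CC(C)(C)n1cc2c(n1)C(=O)CC1(CCN(C(=O)c3cc(-c4ccc(N)cc4)nc4ccccc34)CC1)O2` gives 630 nM
- compound 3 `CN(C)c1ccc(-c2cc(C(=O)N3CCC4(CC3)CC(=O)c3nn(C(C)(C)C)cc3O4)c3ccccc3n2)cc1` gives 1730 nM

Compound 3 has the highest number of the three, which makes it the weakest inhibitor here. The step of a 2.7-fold higher number from compound 1 to compound 3 (0.44 log units; beyond the scatter) and the step of a 2.7-fold higher number from compound 2 to compound 3 (0.44 log units; beyond the scatter) are both modest. Amino in place of chloro on an aromatic carbon gave no change at the digits printed from compound 1 to compound 2 (within the scatter) and so that swap made no measurable difference.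

Compound 4 `CC(C)(C)n1cc2c(n1)C(=O)CC1(CCN(C(=O)c3cc(-c4ccncc4)nc4ccccc34)CC1)O2` has not yet been measured. The change from compound 3 is pyridin-4-yl in place of 4-(dimethylamino)phenyl on an aromatic carbon and the rest of the molecule stays the same. Within the data shown here, it places pyridin-4-yl in place of 4-(dimethylamino)phenyl on an aromatic carbon, and no measured step tests such a ring directly, so the evidence is indirect. Of the three measured compounds, only compound 3 carries dimethylamino, and the step of a 2.7-fold higher number from compound 2 to compound 3 (0.44 log units; beyond the scatter) is the sole measured rise. Removing that group should therefore bring the number back toward compounds 1 and 2.

Among the measured compounds shown here, the expected change is a modest move to a lower number, estimated as a 2.2-fold lower number from compound 3 to compound 4 (0.33 log units; beyond the scatter) in this assay and resting on only three compounds. For compound 4 the estimate is 800 nM with an expected range from 280 nM to 2500 nM in this measurement.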

Compound 4, half-maximal inhibitory concentration: 380 nM
Estimate against measurement, compound 4: 2.1-fold (0.32 log units) above, within the range that was stated.
By their numbers in this assay, from the lowest: compounds 4, 1 and 2 (each within the scatter of the next); then compound 3.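

In this assay, on this aromatic carbon next to the ring nitrogen, swapping 4-(dimethylamino)phenyl for pyridin-4-yl gave a 4.6-fold lower number from compound 3 to compound 4 (0.66 log units; beyond the scatter) and so recovered what the dimethylamino compound had lost, even though the new ring carries a ring nitrogen and has no further group on it. Compound 4 also sits level with the two other compounds, with a 1.7-fold lower number from compound 2 to compound 4 (0.22 log units; within the scatter) against the 4-aminophenyl compound and a 1.7-fold lower number from compound 1 to compound 4 (0.22 log units; within the scatter) against the 4-chlorophenyl compound, so a phenyl ring bearing a chloro or amino group is not needed to keep the number at this level, and among these four compounds only compound 3 stands apart. No measurement of any property is available to explain why the dimethylamino compound differs from the rest.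

The compounds shown leave open whether the ring nitrogen or the absence of a further group on the ring matters more, and a plain phenyl ring at this position would separate the two. Also open, as far as these compounds go, is how this position would respond to pyridin-3-yl, or to a phenyl ring bearing a carboxylic acid or a longer chain.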